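The compounds below may be only part of what the source reports. "The series", "measured", "known", "first", "only" and "open" are said of these compounds alone.

Measured compounds:
compound 1 `O=C1NCCN1c1ccc(S(=O)(=O)Nc2cccc(Br)c2)cc1`: 77 nM
compound 2 `CCc1ccc(NS(=O)(=O)c2ccc(N3CCNC3=O)cc2)cc1`: 660 nM
compound 3 `O=C1NCCN1c1ccc(S(=O)(=O)Nc2cccc(Oc3ccccc3)c2)cc1`: 200 nM

In a functional assay on HT-29 cells (Homo sapiens) for antiproliferative activity, read by sulforhodamine B assay, with a stated time of 48 h (on this read-out higher numbers stand for weaker inhibition and lower numbers for stronger inhibition), compound 1 gives the lowest of the three numbers; the nearest is compound 3 with a 2.6-fold higher number from compound 1 to compound 3 (0.41 log units; beyond the scatter), and the furthest is compound 2 with an 8.6-fold higher number from compound 1 to compound 2 (0.93 log units; beyond the scatter). Compound 4 `O=C1NCCN1c1ccc(S(=O)(=O)Nc2cccc(Cl)c2)cc1` differs from compound 1 by chloro in place of bromo on an aromatic carbon. For the measured compounds named here, no measured step exchanges one halogen for another, so the evidence is indirect: the step of a 2.6-fold higher number from compound 1 to compound 3 (0.41 log units; beyond the scatter) shows that replacing bromo at this position with a larger group weakens activity modestly, while an 8.6-fold higher number from compound 1 to compound 2 (0.93 log units; beyond the scatter) concerns a different position. Chloro is a small exchange, so compound 4 is expected to show at most a small upward step, a 1.4-fold higher number from compound 1 to compound 4 (0.15 log units; within the scatter), much of it within the scatter. The estimate for compound 4 in this assay is 110 nM, ranging from 45 nM to 270 nM.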

Compound 4, half-maximal inhibitory concentration: 55 nM
Estimate against measurement, compound 4: 2.0-fold (0.30 log units) above, and the stated range covers the measured number.
By their numbers in this assay, from the lowest: compounds 4 and 1 (each within the scatter of the next); then compound 3; then compound 2.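

In this assay, for the compounds shown here, the exchange of bromo for chloro gives the first direct halogen comparison at this position, and the two compounds lie within the scatter of each other (a 1.4-fold lower number from compound 1 to compound 4 (0.15 log units; within the scatter)). Phenoxy is separated from chloro as well as from bromo (a 3.6-fold lower number from compound 3 to compound 4 (0.56 log units; beyond the scatter)), and the change on the sulfonamide nitrogen now spans a large step (a 12-fold lower number from compound 2 to compound 4 (1.08 log units; beyond the scatter)). No measurement here explains these steps.

The compounds shown leave open how fluoro, iodo, methoxy, nitrile or an amine would behave at this position. They also leave open whether a halogen elsewhere on this ring would behave alike.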